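Amine substituent swap toward the carbamoyloxy phenylethyl analogue

A few compounds are considered here, and "the series" means these few. Any claim that something is new, unique, unknown or untested is made for them only; others in the source may bear on it.

Measured:
compound 1 `O[C@@H]1Cc2ccccc2[C@H]1NC1CCN(CCCc2c[nH]c3ccc(-n4cnnc4)cc23)CC1`: 75%
compound 2 `COC[C@H](NC1CCN(CCCc2c[nH]c3ccc(-n4cnnc4)cc23)CC1)c1ccccc1`: 93%
compound 3 `CC(=O)Nc1ccc(CNC2CCN(CCCc3c[nH]c4ccc(-n5cnnc5)cc34)CC2)cc1`: 75%

In a functional assay on CHO cells for activation of 5-hydroxytryptamine receptor 1D (Homo sapiens), read by GTPgammaS binding (a lower number here means a smaller maximal response, a higher number a larger maximal response), compound 3 gives 75%, level with compound 1 at the digits shown and, together with compound 1, the lowest of the three numbers. For the measured compounds named here, the distance to compound 2 is the only step from compound 3 that exceeds the scatter: a number 18 percentage points lower from compound 2 to compound 3 (beyond the scatter). The step of no change at the digits printed from compound 1 to compound 3 (within the scatter) confirms that the two smaller groups on the amine nitrogen land in the same place.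

Compound 4 `NC(=O)OC[C@H](NC1CCN(CCCc2c[nH]c3ccc(-n4cnnc4)cc23)CC1)c1ccccc1` is unmeasured. Relative to compound 3 the change is 2-(carbamoyloxy)-1-phenylethyl in place of 4-acetamidobenzyl on an amine nitrogen. The relevant comparison is compound 2, whose substituent on the amine nitrogen is of the same kind as that entering in compound 4, and the step of a number 18 percentage points lower from compound 2 to compound 3 (beyond the scatter) ran the other way. A rise is therefore expected, estimated as a number 13 percentage points higher from compound 3 to compound 4 (beyond the scatter). Going by the values given here, the estimate stays somewhat short of compound 2, which gives 93%; no direct step covers the carbamoyloxy group. For compound 4 the expected value is 88%, with a range from 72% to 102%.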

Compound 4, largest response reached (reported as efficacy), in percent of the reference or control that the assay uses: 73%
Compound 4: the middle estimate sits 15 percentage points above what was measured; the measured number falls inside the stated range.
By their numbers in this assay, from the lowest: compounds 4, 1 and 3 (each within the scatter of the next); then compound 2.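

In this assay, carbamoyl in place of methyl on an oxygen on a saturated carbon gives a number 20 percentage points lower from compound 2 to compound 4 (beyond the scatter), so the 1-phenylethyl frame does not by itself carry the larger maximal response, and the group on that oxygen matters. The other two steps, a number 2 percentage points lower from compound 3 to compound 4 (within the scatter) and a number 2 percentage points lower from compound 1 to compound 4 (within the scatter), place 2-(carbamoyloxy)-1-phenylethyl level with both 4-acetamidobenzyl and 2-hydroxy-2,3-dihydro-1H-inden-1-yl, leaving compound 2 alone above the other three. No supporting data bear on the reason for this drop.

Going by these compounds, whether the larger response is specific to the methyl ether remains open, since compound 2 is the only high point in the set. A free hydroxyl, an ethyl ether or a primary amine on the same carbon would show whether it extends beyond that one group.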